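This account rests on a few compounds, and the source may have more. Where it says the series, first, only, none or still open, it means among the compounds named here.

In a physicochemical assay, read by spectrophotometry, with a stated time of 30 min (on this read-out higher numbers stand for weaker inhibition and lower numbers for stronger inhibition), compound 1 (`COc1cc(/C=N/NC(=O)CCCc2nc3ccccc3c(=O)[nH]2)ccc1O`) gives 236000000 nM and compound 2 (`O=C(CCCc1nc2ccccc2c(=O)[nH]1)N/N=C/c1ccc([N+](=O)[O-])cc1`) gives 316000000 nM while compound 3 (`COc1ccc(/C=N/NC(=O)CCCc2nc3ccccc3c(=O)[nH]2)cc1`) gives 247000000 nM on the same read-out. Compound 3 lies within the scatter of both compound 1 and compound 2, so the three cannot be ranked. Compound 4 (`O=C(CCCc1nc2ccccc2c(=O)[nH]1)N/N=C/c1ccc(O)cc1`) has not yet been measured. Its change from compound 3 is hydrogen in place of methyl on an oxygen on an aromatic ring and reads, in words, hydrogen in place of methyl on an oxygen on an aromatic ring, or 4-methoxyphenyl to 4-hydroxyphenyl. The closest evidence is a 1.0-fold higher number from compound 1 to compound 3 (0.02 log units; within the scatter) for 4-methoxyphenyl in place of 4-hydroxy-3-methoxyphenyl. Placing 4-nitrophenyl on the same carbon gives a 1.3-fold higher number from compound 1 to compound 2 (0.13 log units; within the scatter) and methoxy in place of nitro gives a 1.3-fold lower number from compound 2 to compound 3 (0.11 log units; within the scatter) in turn. All three steps stay within the scatter, although none of them tests the loss of this methyl alone. No step beyond the scatter is therefore expected in this assay for this change. The estimated step is a 1.0-fold higher number from compound 3 to compound 4 (0.01 log units; within the scatter) and no direction is favoured. Compound 4 is estimated at 250000000 nM with an expected range from 150000000 nM to 400000000 nM on this evidence.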

Compound 4, half-maximal inhibitory concentration: 214000000 nM
Compound 4: the middle estimate sits 1.2-fold (0.07 log units) above what was measured; the range from low to high includes it.
By their numbers in this assay, from the lowest: compounds 4, 1, 3 and 2 (each within the scatter of the next).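

In this assay, hydrogen in place of methyl on an oxygen on an aromatic ring is now tested on its own, and it gives a step that stays within the scatter (a 1.2-fold lower number from compound 3 to compound 4 (0.06 log units; within the scatter)), so this assay does not separate 4-methoxyphenyl from 4-hydroxyphenyl at this place. The two other new steps also stay within the scatter, for hydrogen in place of methoxy on an aromatic carbon (a 1.1-fold lower number from compound 1 to compound 4 (0.04 log units; within the scatter)) and for the change from nitro to hydroxy (a 1.5-fold lower number from compound 2 to compound 4 (0.17 log units; within the scatter)), which means that none of the four aromatic groups shown can be told from another on this read-out, and no compound among them goes against this. No evidence is at hand that bears on this result.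

The compounds shown leave open whether an amine or a carboxylic acid on the same aromatic carbon, or a ring other than phenyl on the carbon with a double bond to nitrogen, would give a step beyond the scatter. They also leave open what a longer chain or a shorter chain between the shared core and the carbonyl would do, since all four compounds carry the same chain.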